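The source may report more compounds than this note shows. Statements on the series, on what has been measured and on what is new or still open speak of the compounds shown alone.

Compound 1 `C=C1C2=C(C(=O)N1OC)[C@H](O)[C@@](C)(O)[C@H](CCCCC)O2` carries hydrogen on an oxygen on a saturated carbon of the shared core, and in a functional assay on HCT-116 cells (Homo sapiens) for cytotoxicity, read by MTT assay, with a stated time of 72 h (a lower number here means a stronger inhibitor, a higher number a weaker inhibitor), compound 1 gives 44000 nM. Compound 2 `C=C1C2=C(C(=O)N1OC)[C@H](OC(=O)CCCCCl)[C@@](C)(O)[C@H](CCCCC)O2` carries (4-chlorobutyl)carbonyl in place of that hydrogen, and in this assay compound 2 gives 11000 nM. Going by the values given here, the step of a 4.0-fold lower number from compound 1 to compound 2 (0.60 log units; beyond the scatter) is the only measured step. Among the compounds with values here, on the two numbers measured so far, compound 2 stands lowest, with compound 1 nearest to it.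

Compound 3 `C=C1C2=C(C(=O)N1OC)[C@H](OC(=O)CCl)[C@@](C)(O)[C@H](CCCCC)O2` differs from compound 2 by chloro in place of 3-chloropropyl on a saturated chain carbon bound to a carbonyl carbon. Read one bond further out, the ((4-chlorobutyl)carbonyl)oxy group becomes ((chloromethyl)carbonyl)oxy, so the carbonyl-bearing substituent stays and only its chain is shortened. Within the data shown here, the step of a 4.0-fold lower number from compound 1 to compound 2 (0.60 log units; beyond the scatter) bears on the presence of that substituent, not on the length of its chain; no measured step speaks to chain length. The expectation in this assay is therefore a step of a 1.5-fold higher number from compound 2 to compound 3 (0.16 log units; within the scatter), small and not clearly beyond the scatter, with the range kept wide. Compound 3 is estimated at 16000 nM, between 5000 nM and 50000 nM.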

Compound 3, half-maximal inhibitory concentration: 2400 nM
Beside the measured number, compound 3's estimate is 6.7-fold (0.82 log units) above it; the measured number lies below the stated range.
By their numbers in this assay, from the lowest: compound 3; then compound 2; then compound 1.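

Chain length at this position is now shown to count, not only the presence of the carbonyl-bearing substituent: in this assay, chloro in place of 3-chloropropyl on a saturated chain carbon bound to a carbonyl carbon gives a 4.6-fold lower number from compound 2 to compound 3 (0.66 log units; beyond the scatter). Measured against the hydrogen on the oxygen of the shared core, (chloromethyl)carbonyl gives an 18-fold lower number from compound 1 to compound 3 (1.26 log units; beyond the scatter), a large step, whereas (4-chlorobutyl)carbonyl gave only the modest 4.0-fold lower number from compound 1 to compound 2 (0.60 log units; beyond the scatter), so among these three compounds the size of the gain depends on which chain the substituent carries, with compound 3 lowest. Going by these compounds alone, nothing measured so far offers an explanation for the difference between the chloromethyl and 4-chlorobutyl chains.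

As far as these compounds go, with only these two chains in hand, the shape of the dependence on length remains open, including whether a 2-chloroethyl or 3-chloropropyl chain would fall on a smooth trend between them or whether a longer chain would differ again. From the compounds shown here alone, the role of the chlorine also remains open, as a plain methyl or butyl chain, or an amine in place of the chlorine, would be needed to separate it from chain length.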